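A few compounds are considered here, and "the series" means these few. Any claim that something is new, unique, unknown or untested is made for them only; others in the source may bear on it.

Measured so far:
compound 1 `COc1cc(/C=C/C(=O)c2sc(Nc3ccc(Cl)cc3)nc2C)cc(OC)c1OC` — > 25000 nM
compound 2 `Cc1nc(Nc2ccc(Cl)cc2)sc1C(=O)/C=C/c1ccc(Cl)cc1` — > 25000 nM
compound 3 `Cc1nc(Nc2cccc(Cl)c2)sc1C(=O)/C=C/c1ccc(Cl)cc1` — > 25000 nM

The three compounds were tested in a functional assay on PC-3 cells (Homo sapiens) for cytotoxicity, read by MTT assay; a higher number here means a weaker inhibitor, a lower number a stronger inhibitor. In this assay compound 1 gives > 25000 nM, which is a limit of the assay and not a number. Compound 2 likewise gives > 25000 nM, again a limit. Compound 3 gives > 25000 nM, also a limit. The step from compound 2 to compound 3 is the change (3-chlorophenyl in place of 4-chlorophenyl on a nitrogen on an aromatic ring), and because of the limit of > 25000 nM in this assay, at which 3 of the 3 values shown sit, its size cannot be read: it is a step that the two limits leave unreadable from compound 2 to compound 3. The difference between the cores of compound 1 and compound 2 is not broken down here.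

Compound 4 `COc1cc(/C=C/C(=O)c2sc(Nc3cccc(Cl)c3)nc2C)cc(OC)c1OC` has not yet been measured. It differs from compound 1 by 3-chlorophenyl in place of 4-chlorophenyl on a nitrogen on an aromatic ring, the same change as that from compound 2 to compound 3, made at the same place. Since compound 2 and compound 3 both sit at the limit, and compound 1 sits at the limit as well, compound 4 is expected to stay at the limit too, giving an estimated step that the limit leaves unreadable from compound 1 to compound 4. The estimate for compound 4 in this assay is therefore 60000 nM, with the expected range running from 20000 nM to 300000 nM.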

Compound 4, half-maximal inhibitory concentration: > 25000 nM
Compound 4 was reported as a limit (the forecaster's own chance of this, stated with the estimate: 85%); the middle value does not contradict the limit.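

In this assay, no size can be read for the change between compound 1 and compound 4, so this result gives no new step, because both values are limits of the assay and not numbers: the limit of > 25000 nM in this assay, at which 4 of the 4 values shown sit.

The compounds shown leave open whether 3-chlorophenyl and 4-chlorophenyl differ at all in this assay, and what change would bring a value inside the readable range.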